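The source may hold more compounds than are shown below. What is called first, only, known or untested is meant among the compounds shown, and "the series" means these compounds.

Among the compounds with values here, compound 3 `O=C(O)c1cc(-n2c(-c3ccc(Cl)c(Cl)c3)cc3c2CCCC3)ccc1O` gives 0% in a functional assay on the whole organism (strain Wistar) for inhibition, with Rattus norvegicus as the target, read by paw edema, with stated times of 30 min and 3 h, at a dose of 200 mg/kg by the oral route (a lower number here means less inhibition, a higher number more inhibition at the dose given (going by the name of the read-out)), the lowest of the three numbers measured so far. Compound 1 `COc1ccc(-c2cc3c(n2-c2ccc(O)c(C(=O)O)c2)CCCC3)cc1` gives 50%, and compound 2 `O=C(O)c1cc(-n2c(-c3ccc(Cl)cc3)cc3c2CCCC3)ccc1O` gives 40%. Both a number 50 percentage points lower from compound 1 to compound 3 (beyond the scatter) and a number 40 percentage points lower from compound 2 to compound 3 (beyond the scatter) are large steps beyond the scatter, whereas a number 10 percentage points lower from compound 1 to compound 2 (within the scatter) stays within it. Compound 4 `O=C(O)c1cc(-n2c(-c3ccc(O)cc3)cc3c2CCCC3)ccc1O` carries the change (4-hydroxyphenyl in place of 3,4-dichlorophenyl on an aromatic carbon). Because a number 40 percentage points lower from compound 2 to compound 3 (beyond the scatter) was large while a number 10 percentage points lower from compound 1 to compound 2 (within the scatter) was not, the 3,4-dichlorophenyl group appears to be what sets compound 3 apart, and its removal in compound 4 is expected to return the number to the level shared by compound 1 and compound 2. Compound 4 is therefore estimated at 45%, with a range from 20% to 65%, an expected step of a number 45 percentage points higher from compound 3 to compound 4 (beyond the scatter).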

Compound 4, a percentage reported as inhibition, in the whole organism at one dose (the size of the read-out at that dose, not a potency): 20%
Estimate against measurement, compound 4: 25 percentage points above; low and high end bracket the measured number.
By their numbers in this assay, from the lowest: compound 3; then compound 4; then compounds 2 and 1 (each within the scatter of the next).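

In this assay, the 4-hydroxyphenyl group recovers only part of the gap left by the 3,4-dichlorophenyl group (a number 20 percentage points higher from compound 3 to compound 4 (beyond the scatter)). Single groups at the same place on this phenyl ring now separate: hydroxy falls short of chloro (a number 20 percentage points lower from compound 2 to compound 4 (beyond the scatter)), although chloro and methoxy stayed within the scatter of each other. Removing only the methyl from the methoxy oxygen also counts (a number 30 percentage points lower from compound 1 to compound 4 (beyond the scatter)). As far as these compounds go, whether an amine or a longer alkoxy chain there would follow methoxy or hydroxy remains open. No measurement shown explains why these groups differ.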